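The compounds below may be only part of what the source reports. "The series", "measured", "known", "first", "only" and "open" are said of these compounds alone.

Measured so far:
compound 1 `CSc1ccc(-c2nc3ccc[nH]c-3n2)cc1`: 1.9 mg/kg
compound 2 `CS(=O)(=O)c1ccc(-c2nc3ccc[nH]c-3n2)cc1`: 18 mg/kg
compound 3 `CSc1ccc(-c2nc3cc[nH]cc-3n2)cc1`: 4 mg/kg

All three values come from a functional assay on the whole organism with Canis familiaris (Canis lupus familiaris) as the target; on this read-out lower numbers stand for an effect already at smaller amounts and higher numbers for an effect only at larger amounts of compound. Compound 1 and compound 3 are built from the same atoms joined differently; the difference between their two cores is not broken down here. In this assay compound 1 gives 1.9 mg/kg and compound 3 gives 4 mg/kg. Compound 2 differs from compound 1 in one place: methylsulfonyl in place of methylsulfanyl on an aromatic carbon. In this assay compound 2 gives 18 mg/kg, and the step of a 9.5-fold higher number from compound 1 to compound 2 (0.98 log units; beyond the scatter) lies beyond the scatter. Compound 4 `CS(=O)(=O)c1ccc(-c2nc3cc[nH]cc-3n2)cc1` is not yet measured; it differs from compound 3 by methylsulfonyl in place of methylsulfanyl on an aromatic carbon, the same change in the same place. A step of about a 9.5-fold higher number from compound 3 to compound 4 (0.98 log units; beyond the scatter) is expected because the same change gave a 9.5-fold higher number from compound 1 to compound 2 (0.98 log units; beyond the scatter). Compound 4 is thus estimated at 38 mg/kg, with a likely range from 15 mg/kg to 90 mg/kg.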

Compound 4, dose for half-maximal effect: 7.5 mg/kg
Compound 4: the middle estimate sits 5.1-fold (0.70 log units) above what was measured; measured number below the stated range.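

In this assay, putting methylsulfonyl in place of methylsulfanyl on the core of compound 3 gives a 1.9-fold higher number from compound 3 to compound 4 (0.27 log units; within the scatter), so on this core the change has no effect that can be told from the scatter. The same change does not carry over at the same size from one core to the other: the same change on two cores in this assay, a 9.5-fold higher number (0.98 log units; beyond the scatter) from compound 1 to compound 2 and a 1.9-fold higher number (0.27 log units; within the scatter) from compound 3 to compound 4, 5.1-fold (0.70 log units) apart, beyond the scatter of two such steps This shows that, for these two pairs, the size of the step depends on the core, but it does not show what in the two cores sets them apart, and two pairs give no rule for any further core.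

The compounds shown leave open how an amine or a carboxylic acid in this place would behave on either core. They also leave open what the same change would do on a third core.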